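The source may report more compounds than this note shows. Statements on the series, on what has been measured and on what is new or still open speak of the compounds shown alone.

Compound 1 `CC(C)CN1C(=O)c2ccccc2[C@H](C(=O)Nc2ccc(F)c(C#N)c2)[C@H]1C1CCCNC1`: 54000 nM
Compound 2 `CC(C)CN1C(=O)c2ccccc2[C@H](C(=O)Nc2ccc(F)c(C#N)c2)[C@H]1c1ccncc1`: 55000 nM

Both numbers come from a physicochemical assay for solubility, in phosphate buffer, with a stated time of 18 h, at pH 7; on this read-out higher numbers stand for higher solubility and lower numbers for lower solubility. Compound 2 stands level with compound 1, as the two values lie within the scatter of each other. Among the measured compounds shown here, the one measured step between them is a 1.0-fold higher number from compound 1 to compound 2 (0.01 log units; within the scatter), and it exchanged piperidin-3-yl for pyridin-4-yl on a saturated ring carbon.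

The next structure, compound 3 `CC(C)CN1C(=O)c2ccccc2[C@H](C(=O)Nc2ccc(F)c(C#N)c2)[C@H]1c1cnn(C)c1`, keeps the shared core and changes that same substituent: 1-methyl-1H-pyrazol-4-yl in place of pyridin-4-yl on a saturated ring carbon. The new group, 1-methyl-1H-pyrazol-4-yl, sits on the saturated ring carbon next to the ring nitrogen.

For the measured compounds named here, no measured compound carries this group, so the evidence is thin. Going by the values given here, the only guide is the earlier exchange at this position, and a single step cannot establish a pattern. With compound 2 at 55000 nM as the starting point and only a 1.0-fold higher number from compound 1 to compound 2 (0.01 log units; within the scatter) to go on, no step beyond the scatter is expected in this assay, and neither direction is favoured. The expected step is no change at the digits printed from compound 2 to compound 3 (within the scatter). For compound 3 the estimated value is 55000 nM, with an expected range of 22000 nM to 110000 nM.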

Compound 3, solubility: 36000 nM
Beside the measured number, compound 3's estimate is 1.5-fold (0.18 log units) above it; the range from low to high includes it.
By their numbers in this assay, from the lowest: compounds 3, 1 and 2 (each within the scatter of the next).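

In this assay, the 1-methyl-1H-pyrazol-4-yl group gives a 1.5-fold lower number from compound 2 to compound 3 (0.18 log units; within the scatter) and a 1.5-fold lower number from compound 1 to compound 3 (0.18 log units; within the scatter) so neither step leaves the usual spread of repeat measurements. The earlier compounds had shown this for only one exchange, between piperidin-3-yl and pyridin-4-yl; three different rings on this saturated ring carbon now stand level, and that includes a move from a six-membered aromatic ring with 1 hetero atom to a five-membered aromatic ring with 2 hetero atoms. The numbers themselves describe only what was seen at this position, and nothing at hand accounts for how close they lie.

On these data alone, all three compounds carry a ring at this position, so it remains open whether a carboxylic acid, a primary amine on a longer chain or a plain phenyl ring would also stay level with them in this assay or would stand clearly apart. Also open, as far as these compounds go, is whether this flat picture would hold if the isobutyl group or the nitrile elsewhere on the shared core were exchanged as well.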